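Replacing a propyl chain with a cyclopropylcarbamoyl group

The source may hold more compounds than are shown below. What is called first, only, known or untested is meant among the compounds shown, and "the series" means these compounds.

Three compounds of a shared core have been described so far. Compound 1 `COc1ncc(-c2ccc3nc(NC(=O)NC4CC4)sc3c2)cc1NS(=O)(=O)c1ccc(F)cc1` is tested in a functional assay on A549 cells (Homo sapiens) for antiproliferative activity, read by MTT assay, with a stated time of 72 h; a lower number here means a stronger inhibitor, a higher number a weaker inhibitor; there compound 1 gives 900 nM. Compound 2 `COc1ncc(-c2ccc3nc(NC(=O)NCCN4CCCCC4)sc3c2)cc1NS(=O)(=O)c1ccc(F)cc1`, in this assay, gives 330 nM. For the measured compounds named here, the only step between measured compounds is a 2.7-fold lower number from compound 1 to compound 2 (0.44 log units; beyond the scatter), which shows that the group on the amide-type nitrogen can shift the number, though only modestly. Compound 3 `CCCNc1nc2ccc(-c3cnc(Cl)c(NS(=O)(=O)c4ccc(F)cc4)c3)cc2s1` has in this assay only the entry "not determined" (no result reported), so its standing cannot be told from the data; it is known only as a structure.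

Compound 4 `O=C(Nc1nc2ccc(-c3cnc(Cl)c(NS(=O)(=O)c4ccc(F)cc4)c3)cc2s1)NC1CC1` differs from compound 3 in one place: cyclopropylcarbamoyl in place of propyl on a nitrogen on an aromatic ring. The change turns a propylamino group into a (cyclopropylcarbamoyl)amino group, so that compound 4 carries the same cyclopropylcarbamoyl group that compound 1 carries. Going by the values given here, no measured step bears directly on this exchange, and the step from compound 1 to compound 2 concerns a different position. Because compound 1 gives 900 nM, compound 4, with the same cyclopropylcarbamoyl group, is expected to land in a similar range in this assay, and its value is estimated at 900 nM, between 250 nM and 3500 nM.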

Compound 4, half-maximal inhibitory concentration: 1030 nM
Beside the measured number, compound 4's estimate is 1.1-fold (0.06 log units) below it, within the range that was stated.
By their numbers in this assay, from the lowest: compound 2; then compounds 1 and 4 (each within the scatter of the next).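

In this assay, chloro in place of methoxy on an aromatic carbon gives a 1.1-fold higher number from compound 1 to compound 4 (0.06 log units; within the scatter), so with the cyclopropylcarbamoyl group held constant, these two groups cannot be told apart at this position. For the compounds shown here, the earlier step concerned only the group on the amide-type nitrogen, so this is the first measured look at the aromatic carbon, and it shows a place where one exchange leaves the reading within the scatter, a finding that holds for this single pair only. No measurement on hand explains why the two compounds read alike.

As far as these compounds go, the exchange of propyl for cyclopropylcarbamoyl itself cannot be read, since compound 3 has no result to set against compound 4, and the effect of that change on a nitrogen on an aromatic ring stays unknown. Also open, from the compounds shown here alone, is whether an amine, a nitrile or a longer alkoxy chain on the same aromatic carbon would read like chloro and methoxy, and whether 2-(piperidin-1-yl)ethyl in place of cyclopropyl would bring the same step with chloro present.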